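The source may hold more compounds than are shown below. What is called first, only, known or untested is meant among the compounds shown, and "the series" means these compounds.

Working notes on the series. In an ADME assay on the whole organism (Rattus norvegicus, strain Sprague-Dawley), read by LC-MS (on this read-out lower numbers stand for a shorter-lived compound and higher numbers for a longer-lived compound), compound 1 `N#Cc1ccc(S(=O)(=O)[C@H]2CN(S(=O)(=O)c3ccc(C#N)cc3Cl)C[C@@]2(O)CO)cc1` gives 1 h, compound 2 `N#Cc1ccc(S(=O)(=O)N2C[C@H](S(=O)(=O)c3ccc(Cl)cn3)[C@](O)(CO)C2)c(Cl)c1` gives 1.4 h and compound 3 `N#Cc1ccc(S(=O)(=O)N2C[C@H](S(=N)(=O)c3ccc(Cl)cc3)[C@](O)(CO)C2)c(Cl)c1` gives 1 h. Compound 2 stands within the scatter of both others, so the three numbers set no meaningful order.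

The next comparison is compound 4 `N#Cc1ccc(S(=O)(=O)N2C[C@H](S(=O)(=O)c3ccc(Cl)cn3)[C@](O)(CN)C2)c(Cl)c1`, which differs from compound 2 as follows: amino in place of hydroxy on a saturated chain carbon bound to a saturated ring carbon. This reads as hydroxymethyl to aminomethyl, on a saturated ring carbon.

Among the compounds with values here, two measured steps bear on it, and only indirectly: a 1.4-fold higher number from compound 1 to compound 2 (0.15 log units; within the scatter) and a 1.4-fold lower number from compound 2 to compound 3 (0.15 log units; within the scatter). Both are small and lie within the scatter, but neither alters the hydroxymethyl group. Within the data shown here, no measured compound carries the aminomethyl group, so the data offer no direct precedent and no firm direction.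

Among the measured compounds shown here, with these two steps as the only guide, the expected step in this assay is a 1.1-fold higher number from compound 2 to compound 4 (0.03 log units; within the scatter), with nothing expected beyond the scatter. The range is kept wide for the untested change. For compound 4 the estimated value is 1.5 h, with an expected range of 0.7 h to 3.2 h.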

Compound 4, mean residence time: 1.9 h
Beside the measured number, compound 4's estimate is 1.3-fold (0.10 log units) below it; the measured number falls inside the stated range.
By their numbers in this assay, from the lowest: compounds 1, 3, 2 and 4 (each within the scatter of the next).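

Hydroxymethyl to aminomethyl on this saturated ring carbon now has a direct reading: in this assay the change gives a 1.4-fold higher number from compound 2 to compound 4 (0.13 log units; within the scatter), where compounds 1, 2 and 3 all carry hydroxymethyl and could say nothing about this group. On this read-out, then, amino in place of hydroxy on a saturated chain carbon bound to a saturated ring carbon is tolerated within the scatter, though this rests on a single pair. No measurement available here accounts for the step.

As far as these compounds go, whether a carboxylic acid, a methoxy group or a longer chain at this place would also stay within the scatter remains open. Also open, from the compounds shown here alone, is whether the same exchange reads alike with 4-cyanophenyl on the sulfonyl sulfur, as in compound 1.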